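Tail amine swap on a shared quinoline ether scaffold

The source may report more compounds than this note shows. Statements on the series, on what has been measured and on what is new or still open speak of the compounds shown alone.

Measured so far:
- compound 1 `COc1cc2c(Oc3ccc(NC(=O)c4nn(-c5ccccc5C(F)(F)F)c(=O)cc4C)cc3F)ccnc2cc1OCCCN1CCN(C)CC1`: 240 nM
- compound 2 `COc1cc2c(Oc3ccc(NC(=O)c4nn(-c5ccccc5OC(F)(F)F)c(=O)cc4C)cc3F)ccnc2cc1OCCCN1CCCC1`: 210 nM

Within the data shown here, in a functional assay on NCI-H460 cells (Homo sapiens) for inhibition, read by MTT assay, with a stated time of 72 h (a lower number here means a stronger inhibitor, a higher number a weaker inhibitor), compound 2 gives 210 nM, the lower of the two numbers so far, with compound 1 nearest at 240 nM; the two values lie within the usual scatter of each other, so neither compound can be set above the other. Among the measured compounds shown here, compound 1 and compound 2 differ in two places at once, so no single step between them can be read.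

Compound 3 `COc1cc2c(Oc3ccc(NC(=O)c4nn(-c5ccccc5OC(F)(F)F)c(=O)cc4C)cc3F)ccnc2cc1OCCCN1CCN(C)CC1` has not yet been measured. It keeps the core of compound 2 and differs only in the tail: 4-methylpiperazin-1-yl in place of pyrrolidin-1-yl on a saturated chain carbon, three bonds along the chain from an oxygen on an aromatic ring. The same tail amine is already carried by compound 1, which sits within the scatter of compound 2. On that basis no step beyond the scatter is expected in this assay. Compound 3 is estimated at 230 nM (range 110 nM to 500 nM), an expected step of a 1.1-fold higher number from compound 2 to compound 3 (0.04 log units; within the scatter).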

Compound 3, half-maximal inhibitory concentration: 260 nM
Beside the measured number, compound 3's estimate is 1.1-fold (0.05 log units) below it; the measured number falls inside the stated range.
By their numbers in this assay, from the lowest: compounds 2, 1 and 3 (each within the scatter of the next).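

In this assay the tail change can now be read on its own with the rest of compound 2 held fixed: 4-methylpiperazin-1-yl in place of pyrrolidin-1-yl gives a 1.2-fold higher number from compound 2 to compound 3 (0.09 log units; within the scatter) and so stays within the scatter. Compound 3 also ties compound 1 into the series through a single change, trifluoromethoxy in place of trifluoromethyl on an aromatic carbon, which gives a 1.1-fold higher number from compound 1 to compound 3 (0.03 log units; within the scatter) and likewise stays within the scatter. Both amine tails are therefore accommodated at this chain end with no separable change in the number, and the same holds for the two fluorinated aromatic substituents with the 4-methylpiperazin-1-yl tail in place.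

As far as these compounds go, whether a morpholin-4-yl tail, a carboxylic acid at the chain end or a butyl chain in place of propyl would also stay within the scatter remains open. Nothing at hand explains why these two changes leave the number in place.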